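The source may hold more compounds than are shown below. What is called first, only, known or untested is meant among the compounds shown, and "the series" means these compounds.

Measured compounds:
- compound 1, `CC1Cc2ccccc2N1S(=O)(=O)c1ccc(-c2cnc(C3CC3)o2)cc1`: 61.3%
- compound 2, `Cc1ccc2c(c1)CCN2S(=O)(=O)c1ccc(-c2cnc(C3CC3)o2)cc1`: 74.7%

In an ADME assay on HEK-293T cells (Homo sapiens) for inhibition, read by MTT assay, tested at 10 uM (on this read-out lower numbers stand for less inhibition and higher numbers for more inhibition at the one concentration tested (going by the name of the read-out)), compound 2 gives 74.7%, the higher of the two numbers measured. Compound 1 gives 61.3% in this assay, and the gap between compound 1 and compound 2 lies beyond the scatter of repeated measurements, so compound 2 stands clearly above compound 1.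

Compound 3, `CS(=O)(=O)c1ccc2c(c1)CCN2S(=O)(=O)c1ccc(-c2cnc(C3CC3)o2)cc1`, has not been measured in this assay. It differs from compound 2 by methylsulfonyl in place of methyl on an aromatic carbon. Among the compounds with values here, no step between measured compounds covers a change of this kind, so there is nothing to set its size or direction. The step expected is a number 9.7 percentage points lower from compound 2 to compound 3 (within the scatter), downward but modest, and it may well fall within the scatter. Compound 3 is therefore expected to give about 65% in this assay, with a range from 45% to 85%.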

Compound 3, a percentage reported as inhibition, at one concentration (the size of the read-out at that concentration, not a potency): 6.54%
The estimate for compound 3 lay 58.5 percentage points above the measured number; measured number outside the range, below it.
By their numbers in this assay, from the lowest: compound 3; then compound 1; then compound 2.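

In this assay, the group on this aromatic carbon, meta to a fused ring and para to a fused ring, has a strong bearing on the read-out: methylsulfonyl in place of methyl gives a number 68.2 percentage points lower from compound 2 to compound 3 (beyond the scatter) and leaves compound 3 at 6.54%. The series thus gains its first single-place step, and it shows that inhibition at the one concentration tested is not fixed by the shared core alone. The change adds two hydrogen-bond acceptors and three heavy atoms, but nothing measured here accounts for the fall.

On these data alone, whether the fall in this assay is particular to methylsulfonyl or would also follow a nitrile, a methoxy group or an amine on the same carbon stays open. Also open, as far as these compounds go, is how methylsulfonyl would behave on another carbon of that ring.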